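The compounds below may be only part of what the source reports. "The series", "measured", "known", "first", "only" and "open" are said of these compounds alone.

Measured so far in an assay on HEK293 cells for inhibition of kynurenine 3-monooxygenase (Homo sapiens), read by LC-MS, with a stated time of 20 h; a lower number here means a stronger inhibitor, a higher number a weaker inhibitor:

compound 1 `O=C(O)CCn1c(=O)oc2cc(Cl)c(Cl)cc21`: 2000 nM
compound 2 `O=C(O)CCn1c(=O)oc2cc(OCc3ccccc3)c(Cl)cc21`: 1580 nM

Among the compounds with values here, compound 2 holds the lowest of the two numbers in this assay, but its only neighbour is compound 1, and the step of a 1.3-fold lower number from compound 1 to compound 2 (0.10 log units; within the scatter) does not separate the two. Within the data shown here, the series gives no compound whose number sits beyond the scatter from compound 2.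

Compound 3 `C[C@@H](Oc1cc2oc(=O)n(CCC(=O)O)c2cc1Cl)c1ncccn1` is the next compound to be measured in this assay. Relative to compound 2 the change is a group of 8 heavy atoms (6 carbon, 2 nitrogen; one six-membered aromatic ring with 2 hetero atoms) in place of a group of 7 heavy atoms (7 carbon; one six-membered aromatic ring of carbon only), on an oxygen on an aromatic ring.

Among the measured compounds shown here, the only measured step, from compound 1 to compound 2, exchanged a chloro for a benzyloxy and lay within the scatter. For the measured compounds named here, no measured step touches a change on the oxygen on the aromatic ring itself, so nothing seen here points to a shift in either direction. Compound 3 is therefore expected to give a number close to that of compound 2, with the step of a 1.2-fold lower number from compound 2 to compound 3 (0.08 log units; within the scatter) expected to stay within the scatter. The estimate for compound 3 in this assay is 1300 nM, with a range from 400 nM to 4000 nM.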

Compound 3, half-maximal inhibitory concentration: 3160 nM
For compound 3 the middle estimate is 2.4-fold (0.39 log units) below the measured one; the measured number falls inside the stated range.
By their numbers in this assay, from the lowest: compounds 2, 1 and 3 (each within the scatter of the next).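

In this assay, within the data shown here, the one step on the oxygen on an aromatic ring reads a 2.0-fold higher number from compound 2 to compound 3 (0.30 log units; within the scatter) and does not separate the two compounds. At this position, then, benzyl and a group with a six-membered aromatic ring with 2 hetero atoms, 2 hydrogen-bond acceptors and 1 defined stereocentre cannot be told apart, although these features all enter together in a single step. Nothing available explains the numbers for this series.

The separate contributions of the ring, its hetero atoms and the stereocentre remain unresolved, as does the opposite configuration at that stereocentre. Also open, on these data alone, is how a much smaller or differently built group on the same oxygen would read, such as methyl or a longer chain ending in an amine.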